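A few compounds are considered here, and "the series" means these few. Any claim that something is new, unique, unknown or untested is made for them only; others in the source may bear on it.

In a functional assay on SW-620 cells (Homo sapiens) for cytotoxicity, read by MTT assay, with a stated time of 72 h (a higher number here means a weaker inhibitor, a lower number a stronger inhibitor), compound 1 `COc1cccc(/C=C2\CCC/C(=C\c3ccc(Br)cc3)C2=O)c1OC` gives 11100 nM and compound 2 `COc1ccc(/C=C2\CCC/C(=C\c3ccc(Br)cc3)C2=O)cc1OC` gives 5200 nM. Compound 2 therefore holds the lower of the two numbers, making it the stronger inhibitor of this pair, and the gap between the two values lies beyond the usual scatter. Compound 3 `COc1ccc(/C=C2\CCC/C(=C\c3ccc(Cl)cc3Cl)C2=O)cc1OC` departs from compound 2 in one place: 2,4-dichlorophenyl in place of 4-bromophenyl on a double-bonded chain carbon bound to a double-bonded ring carbon. There, 2,4-dichlorophenyl stands in place of 4-bromophenyl on a double-bonded chain carbon bound to a double-bonded ring carbon. Among the measured compounds shown here, no measured pair in this small set shows what a change at that place does, so the only anchor for the expectation is compound 2 at 5200 nM. The data give no firm ground for predicting a move in either direction, and no step beyond the scatter is expected in this assay. The estimated change, a 1.2-fold lower number from compound 2 to compound 3 (0.06 log units; within the scatter), is slight and points toward a stronger inhibitor. For compound 3 the estimated value is 4500 nM, with an expected range from 1500 nM to 13000 nM.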

Compound 3, half-maximal inhibitory concentration: 10300 nM
Compound 3: middle estimate off by 2.3-fold (0.36 log units), on the low side; low and high end bracket the measured number.
By their numbers in this assay, from the lowest: compounds 2, 3 and 1 (each within the scatter of the next, the first and the last beyond it).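

In this assay, among the compounds shown here, putting 2,4-dichlorophenyl in place of 4-bromophenyl on a double-bonded chain carbon bound to a double-bonded ring carbon gives a 2.0-fold higher number from compound 2 to compound 3 (0.30 log units; within the scatter), the first reading of any change at this place, since compound 1 and compound 2 both carry 4-bromophenyl there. The step does not separate the two groups in this assay, so at this position the exchange of one for the other, with its added halogen and its change from bromine to chlorine, leaves compound 2 and compound 3 indistinguishable on these numbers. No measurement at hand speaks to what lies behind this reading.

The compounds shown leave open whether a group without halogen at this place, such as an unsubstituted phenyl, or one carrying an amine or a carboxylic acid, would read apart from 4-bromophenyl in this assay. Also open, from the compounds shown here alone, is whether the same exchange of 4-bromophenyl for 2,4-dichlorophenyl would stay as small on the core of compound 1, and whether either chlorine alone would match the pair.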